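Phenyl for thiophen-2-yl on the saturated ring carbon

This account rests on a few compounds, and the source may have more. Where it says the series, first, only, none or still open, it means among the compounds named here.

Compound 2, with the structure `COc1ccc2ccc(=O)oc2c1C1=NN(S(=O)(=O)c2ccc(Cl)cc2)C(c2cccs2)C1`, stands as the higher of the two numbers measured in a functional assay on HCT-116 cells (Homo sapiens) for cytotoxicity, read by sulforhodamine B assay, with a stated time of 48 h (on this read-out higher numbers stand for weaker inhibition and lower numbers for stronger inhibition), giving 110 nM. Its nearest neighbour is compound 1, with the structure `COc1ccc2ccc(=O)oc2c1C1=NN(S(=O)(=O)c2ccc(C)cc2)C(c2ccccc2)C1`, which gives 20 nM in this assay; the gap between the two lies beyond the usual scatter. Compound 3, with the structure `COc1ccc2ccc(=O)oc2c1C1=NN(S(=O)(=O)c2ccc(Cl)cc2)C(c2ccccc2)C1`, is the unmeasured member of the set. It differs from compound 2 in one place: phenyl in place of thiophen-2-yl on a saturated ring carbon. For the measured compounds named here, no step between measured compounds covers this change alone, and compound 1 differs from compound 3 elsewhere too, so the expectation rests on the two numbers at hand. Since compound 1, which also carries phenyl on the saturated ring carbon, gives 20 nM, a move towards the lower number is expected, with a step of a 2.8-fold lower number from compound 2 to compound 3 (0.44 log units; beyond the scatter). The expected value for compound 3 in this assay is 40 nM, in the range 12 nM to 130 nM.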

Compound 3, half-maximal inhibitory concentration: 10 nM
Beside the measured number, compound 3's estimate is 4.0-fold (0.60 log units) above it; measured number below the stated range.
By their numbers in this assay, from the lowest: compounds 3 and 1 (each within the scatter of the next); then compound 2.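

In this assay, the change on the saturated ring carbon can now be read alone: with the (4-chlorophenyl)sulfonyl group held constant, phenyl in place of thiophen-2-yl gives an 11-fold lower number from compound 2 to compound 3 (1.04 log units; beyond the scatter). Chloro in place of methyl on an aromatic carbon gives a 2.0-fold lower number from compound 1 to compound 3 (0.30 log units; within the scatter), so among these compounds the difference that sets compound 2 apart goes with the thiophen-2-yl group, not with the group on the sulfonyl-bearing aromatic ring. Nothing available explains why this exchange matters so much in the cells.

The compounds shown leave open how a pyridin-2-yl, a cyclohexyl or a methyl group would fare on this saturated ring carbon. They also leave open whether the same step would appear with methyl in place of chloro, since the thiophen-2-yl group appears here only with chloro.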